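Thioester Variant of an Inactive Iridoid Ester Series

The source may report more compounds than this note shows. Statements on the series, on what has been measured and on what is new or still open speak of the compounds shown alone.

This account concerns three glycosylated esters tested in a functional assay on SK-BR-3 cells (Homo sapiens) for antiproliferative activity, read by MTT assay, with a stated time of 72 h (a lower number here means a stronger inhibitor, a higher number a weaker inhibitor), and a fourth, unmeasured relative. Compound 1 `C/C=C1/[C@H](O[C@@H]2O[C@H](COC(C)=O)[C@@H](OC(C)=O)[C@H](OC(C)=O)[C@H]2OC(C)=O)OC=C(C(=O)OC)[C@H]1CC(=O)OCCC1CCCCC1` sits at the limit of this assay, giving > 15000 nM. Compound 2 `C/C=C1/[C@H](O[C@@H]2O[C@H](COC(C)=O)[C@@H](OC(C)=O)[C@H](OC(C)=O)[C@H]2OC(C)=O)OC=C(C(=O)OC)[C@H]1CC(=O)OCC` also stands at the limit, with > 15000 nM. Compound 3 `C=C(C)CCOC(=O)C[C@@H]1C(C(=O)OC)=CO[C@@H](O[C@@H]2O[C@H](COC(C)=O)[C@@H](OC(C)=O)[C@H](OC(C)=O)[C@H]2OC(C)=O)/C1=C/C` stands at the limit as well, recorded as > 15000 nM. Because all three values sit at the limit of > 15000 nM in this assay, at which 3 of the 3 values shown sit, the steps between them are unreadable: the change from compound 1 to compound 2 gives a step that the two limits leave unreadable from compound 1 to compound 2, from compound 1 to compound 3 a step that the two limits leave unreadable from compound 1 to compound 3, and from compound 2 to compound 3 a step that the two limits leave unreadable from compound 2 to compound 3.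

Compound 4 `C/C=C1/[C@H](O[C@@H]2O[C@H](COC(C)=O)[C@@H](OC(C)=O)[C@H](OC(C)=O)[C@H]2OC(C)=O)OC=C(C(=O)OC)[C@H]1CC(=O)SCCc1ccccc1` differs from compound 3 by phenethylsulfanyl in place of (3-methylbut-3-en-1-yl)oxy on a carbonyl carbon. For the measured compounds named here, none of the measured steps touches this kind of change, since every measured step altered only the group on a saturated chain carbon, two bonds along the chain from an oxygen next to a carbonyl group, and none of them could be read. The series gives no sign of measurable activity, so the step is expected to stay within the scatter, namely a number no higher from compound 3 to compound 4 (the limit leaves the size open). Compound 4 is therefore expected to give about 15000 nM in this assay, within a range from 5000 nM to 40000 nM.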

Compound 4, half-maximal inhibitory concentration: > 15000 nM
Compound 4 was reported as a limit; the forecaster's own chance of this, stated with the estimate: 70%; the middle value lies on the limit itself.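

In this assay compound 4 gives > 15000 nM, which is a limit and not a number. Its steps from compound 1, compound 2 and compound 3 cannot be read, because all four values stand at the same limit: the limit of > 15000 nM in this assay, at which 4 of the 4 values shown sit. The compounds shown leave open how phenethylsulfanyl truly compares with the groups it replaces, and whether any of the four compounds has measurable activity.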